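The source may report more compounds than this note shows. Statements on the series, on what has been measured and on what is new or still open speak of the compounds shown alone.

Compound 2 `CC[C@H](C)[C@H](NC(=O)CN(c1ncnc2c1ncn2C1CCCCO1)C1CC1)C(=O)OCc1ccccc1` is the lower of the two compounds measured in a functional assay on the whole organism (Tail, strain ICR) with Mus musculus as the target, in the tail flick test, with a stated time of 30 min, at a dose of 25 umol/kg by the oral route; a higher number here means a stronger effect of the compound at the dose given, a lower number a weaker effect: there compound 2 gives 25.6%, while compound 1 `O=C(CN(c1ncnc2c1ncn2C1CCCCO1)C1CC1)NCC(=O)OCc1ccccc1` gives 55.7%. Among the measured compounds shown here, the one measured step between them, a number 30.1 percentage points lower from compound 1 to compound 2 (beyond the scatter), is the only comparison on record. Compound 3 `C[C@@H](O)[C@H](NC(=O)CN(c1ncnc2c1ncn2C1CCCCO1)C1CC1)C(=O)OCc1ccccc1` differs from compound 2 in one place: hydroxy in place of ethyl on a saturated chain carbon bound to two saturated chain carbons. For the measured compounds named here, no measured pair shows a hydroxy entering in place of an ethyl at that place, so that step bears on the question only loosely, as the sole sign that the group at that place matters in this assay. Since hydroxy in place of ethyl removes part of the group that entered in a number 30.1 percentage points lower from compound 1 to compound 2 (beyond the scatter), compound 3 is expected to land between the two measured values rather than under compound 2, and the change is expected to read a number 10.4 percentage points higher from compound 2 to compound 3 (beyond the scatter). Compound 3 is therefore estimated at 36%, in a range from 12% to 60%.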

Compound 3, a percentage reported as activity, at one dose (the size of the read-out at that dose, not a potency): 23.6%
For compound 3 the middle estimate is 12.4 percentage points above the measured one; the range from low to high includes it.
By their numbers in this assay, from the lowest: compounds 3 and 2 (each within the scatter of the next); then compound 1.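

In this assay, hydroxy in place of ethyl on a saturated chain carbon bound to two saturated chain carbons gives a number 2 percentage points lower from compound 2 to compound 3 (within the scatter), so the compounds shown do not separate these two groups at this place, even though hydroxy brings a hydrogen-bond donor and acceptor that ethyl lacks. 1-Hydroxyethyl in place of hydrogen on a saturated chain carbon bound to an amide-type nitrogen and a carbonyl carbon gives a number 32.1 percentage points lower from compound 1 to compound 3 (beyond the scatter), so the large step is no longer tied to sec-butyl alone. No available evidence accounts for this result.

On these data alone, whether a methyl or an amine on that same carbon would stay with compound 1 or with compounds 2 and 3 remains open. So does whether a carboxylic acid in place of the benzyl ester would alter this picture.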